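Swapping bromo for hydrogen on compound 3

This account rests on a few compounds, and the source may have more. Where it says the series, first, only, none or still open, it means among the compounds named here.

Values in a functional assay on HeLa cells (Homo sapiens) for cytotoxicity; on this read-out higher numbers stand for weaker inhibition of growth and lower numbers for stronger inhibition of growth:
- compound 1 `COc1ccc(NS(=O)(=O)c2c(F)c(F)c(F)c(Br)c2F)cc1`: 220 nM
- compound 2 `COc1ccc(NS(=O)(=O)c2c(F)cc(F)c(F)c2F)cc1`: 5800 nM
- compound 3 `COc1ccc(NS(=O)(=O)c2c(F)c(F)c(Br)c(F)c2F)cc1`: 17000 nM
- compound 4 `COc1ccc(NS(=O)(=O)c2c(F)c(F)cc(F)c2F)cc1`: not yet measured

Compound 3 stands highest of the three in this assay, beyond the scatter from both other compounds. Compound 4 differs from compound 3 as follows: hydrogen in place of bromo on an aromatic carbon. This places hydrogen in place of bromo on an aromatic carbon. Among the measured compounds shown here, the one measured step of this kind, a 26-fold higher number from compound 1 to compound 2 (1.42 log units; beyond the scatter), was large, but it started from a much lower number and from bromo at another place on the ring. A rise of that size is therefore not expected here, only a small rise near the scatter. Compound 4 is expected at 25000 nM, with a range from 7000 nM to 80000 nM. The estimated change is a 1.5-fold higher number from compound 3 to compound 4 (0.17 log units; within the scatter).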

Compound 4, concentration for 50% growth inhibition: > 50000 nM
Compound 4 ended at the assay's limit; the forecaster's own chance of this, stated with the estimate: 30%; at least 2.0-fold (0.30 log units) between middle value and limit.
By their numbers in this assay, from the lowest: compound 1; then compound 2; then compound 3. At a limit, above all of these: compound 4.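

In this assay, compound 4 gives > 50000 nM, which is a limit of the assay and not a number. Even from the weak end of the series, removing bromo from this position, para to a large group, still has a measurable effect: the step is an at least 2.9-fold higher number from compound 3 to compound 4 (0.46 log units; beyond the scatter). Hydrogen in place of bromo thus raises the number at both positions shown, but the two sizes cannot be compared: the same change on two cores in this assay, a 26-fold higher number (1.42 log units; beyond the scatter) from compound 1 to compound 2 and an at least 2.9-fold higher number (0.46 log units; beyond the scatter) from compound 3 to compound 4; the limit leaves it open whether they differ

From the compounds shown here alone, what an amine or a carboxylic acid at this position would give in this assay remains open. So does the true value of compound 4 beyond its limit.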